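Lengthening a Sulfonamide Chain: A Binding Forecast

The source may report more compounds than this note shows. Statements on the series, on what has been measured and on what is new or still open speak of the compounds shown alone.

Compound 1 `O=[N+]([O-])c1ccc2[nH]c(Cc3ccc(Oc4ccccc4)cc3)nc2c1` gives 1200 nM in an assay on membranes from brain for binding affinity to Adrenergic receptor alpha-1 (Rattus norvegicus) (a higher number here means a weaker inhibitor, a lower number a stronger inhibitor), and in this assay compound 2 `CS(=O)(=O)Nc1ccc2[nH]c(Cc3ccc(Oc4ccccc4)cc3)nc2c1` gives 4000 nM. The step of a 3.3-fold higher number from compound 1 to compound 2 (0.52 log units; beyond the scatter) leaves compound 2 with the higher of the two numbers. Compound 3 `CCS(=O)(=O)Nc1ccc2[nH]c(Cc3ccc(Oc4ccccc4)cc3)nc2c1` differs from compound 2 by methyl in place of hydrogen on a saturated chain carbon bound to a sulfonyl sulfur. Going by the values given here, the only measured step, a 3.3-fold higher number from compound 1 to compound 2 (0.52 log units; beyond the scatter), swaps an entirely different group, so it does not bear on this change, and no other step touches this chain. For compound 3 the expected step is no change at the digits printed from compound 2 to compound 3 (within the scatter), within the usual scatter. Compound 3 is estimated at 4000 nM, between 1500 nM and 11000 nM.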

Compound 3, half-maximal inhibitory concentration: 2800 nM
For compound 3 the middle estimate is 1.4-fold (0.15 log units) above the measured one, within the range that was stated.
By their numbers in this assay, from the lowest: compound 1; then compounds 3 and 2 (each within the scatter of the next).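

In this assay, going from methanesulfonamido to (ethylsulfonyl)amino gives a 1.4-fold lower number from compound 2 to compound 3 (0.15 log units; within the scatter), so adding this methyl to the chain produces no readable change. Replacing nitro with (ethylsulfonyl)amino gives a 2.3-fold higher number from compound 1 to compound 3 (0.37 log units; beyond the scatter), which leaves compound 1 with the lowest number of the three, beyond the scatter from both sulfonamides.

On these data alone, whether a longer chain such as propyl, or a phenyl group on the sulfonyl sulfur, would shift the number remains open. No measurement shown here accounts for either step.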